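Swapping the aryl group on a shared core

The compounds below may be only part of what the source reports. "The series", "measured", "known", "first", "only" and "open" are said of these compounds alone.

Measured compounds:
Compound 1, `C=CCn1c(=O)/c(=C\c2cc(F)ccc2C)[nH]c(=O)/c1=C\c1ccccc1OC`: 7300 nM
Compound 2, `C=CCn1c(=O)/c(=C\c2cc(OC)c(OC)c(OC)c2)[nH]c(=O)/c1=C\c1cccc(Br)c1`: "not active" (no number reported)
Compound 3, `COc1ccccc1/C=c1/[nH]c(=O)/c(=C\c2cccc(Cl)c2Cl)[nH]c1=O`: "not active" (no number reported)

Three compounds built on the same core were tested in a functional assay on NCI-H1975 cells (Homo sapiens) for cytotoxicity, read by CCK-8 assay, with a stated time of 72 h; a lower number here means a stronger inhibitor, a higher number a weaker inhibitor. For the measured compounds named here, compound 1 is the only one with a number; in this assay compound 1 gives 7300 nM. Compound 2 gives "not active" (no number reported) in this assay, with no number reported. Compound 3 likewise gives "not active" (no number reported) in this assay, again without a number. Compound 1 therefore stands as the sole measured reference point.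

The next compound, compound 4, `C=CCn1c(=O)/c(=C\c2ccccc2Cl)[nH]c(=O)/c1=C\c1ccccc1OC`, differs from compound 1 in one place: 2-chlorophenyl in place of 5-fluoro-2-methylphenyl on a double-bonded chain carbon bound to an aromatic carbon. Going by the values given here, no measured pair shows what such a swap does on this core, so the expectation rests on compound 1 alone. Compound 3, which also carries chlorine on that aryl group, gives "not active" (no number reported), but it differs from compound 1 in more than one place, so it cannot fix the size of the step.

The step from compound 1 to compound 4 is expected to be small, toward a weaker inhibitor, at about a 1.5-fold higher number from compound 1 to compound 4 (0.18 log units; within the scatter). Compound 4 is estimated at 11000 nM in this assay, within 3500 nM to 35000 nM.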

Compound 4, half-maximal inhibitory concentration: 9200 nM
The estimate for compound 4 lay 1.2-fold (0.08 log units) above the measured number; the measured number falls inside the stated range.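

In this assay, for the compounds shown here, the swap gives a 1.3-fold higher number from compound 1 to compound 4 (0.10 log units; within the scatter), the first step on the shared core that can be read at all. Going by these compounds alone, on a double-bonded chain carbon bound to an aromatic carbon, 2-chlorophenyl and 5-fluoro-2-methylphenyl therefore cannot be told apart in this test, even though the two groups carry different halogens and only one has a methyl group. No supporting measurement bears on this result.

This single pair cannot show whether the same holds with other groups at this place, such as a phenyl ring carrying an amine or a carboxylic acid, or a longer carbon chain in place of the ring. It also leaves open whether a change at this place could produce a step beyond the scatter in either direction.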